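Benzyl ring substitution pattern and microsomal half-life

The source may hold more compounds than are shown below. What is called first, only, known or untested is meant among the compounds shown, and "the series" means these compounds.

Working notes on the sulfonyl guanidine series. In an ADME assay on microsomes from liver (Homo sapiens) for metabolic stability, read by LC-MS, using NADPH, tested at 5 uM (on this read-out lower numbers stand for a shorter-lived compound and higher numbers for a longer-lived compound), compound 1 `Cc1cc(-c2ccccc2)n(/C(N)=N/S(=O)(=O)c2cc(C)c(Cl)cc2SCc2cccc(C(F)(F)F)c2)n1` gives 0.169 h. Compound 2 `Cc1cc(S(=O)(=O)/N=C(\N)n2nccc2-c2ccccc2)c(SCc2cccc(C(F)(F)F)c2)cc1Cl`, which lacks the methyl on the core, gives 0.0863 h in this assay, the step being a 2.0-fold lower number from compound 1 to compound 2 (0.29 log units; within the scatter). Compound 3 `Cc1cc(S(=O)(=O)/N=C(\N)n2nccc2-c2ccccc2)c(SCc2ccccc2Cl)cc1Cl` gives 0.226 h in this assay, with a 2.6-fold higher number from compound 2 to compound 3 (0.42 log units; beyond the scatter). On the three numbers, compound 1 sits between compound 3 and compound 2 and is within the scatter of each, so no order among these three can be claimed; only compound 3 against compound 2 is a step beyond the scatter.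

Compound 4 `Cc1cc(-c2ccccc2)n(/C(N)=N/S(=O)(=O)c2cc(C)c(Cl)cc2SCc2ccccc2C(F)(F)F)n1` is the next case; the change from compound 1 is 2-(trifluoromethyl)phenyl in place of 3-(trifluoromethyl)phenyl on a saturated chain carbon bound to a sulfur. Among the measured compounds shown here, of the measured steps, only the one from compound 2 to compound 3 touches the same place, and it exchanged the whole aryl group rather than shifting the trifluoromethyl within it; it was modest. The step from compound 1 to compound 2 lies elsewhere on the molecule and does not bear on this change. For the measured compounds named here, no measured pair isolates the shift of the trifluoromethyl alone. The expectation for compound 4 in this assay is therefore no step beyond the scatter, estimated at a 1.2-fold higher number from compound 1 to compound 4 (0.07 log units; within the scatter). Compound 4 is expected to give about 0.2 h, in a range of 0.1 h to 0.4 h.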

Compound 4, half-life: 0.306 h
Compound 4: the middle estimate sits 1.5-fold (0.18 log units) below what was measured; the measured number falls inside the stated range.
By their numbers in this assay, from the lowest: compounds 2, 1, 3 and 4 (each within the scatter of the next, the first and the last beyond it).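

Among the compounds shown here, compound 1 and compound 4 form the first pair that isolates a shift of the trifluoromethyl on the benzyl ring, with the same atoms, the same core and the same place, on a saturated chain carbon bound to a sulfur. In this assay the shift from 3-(trifluoromethyl)phenyl to 2-(trifluoromethyl)phenyl gives a 1.8-fold higher number from compound 1 to compound 4 (0.26 log units; within the scatter), so on the core of compound 1 this pair shows no separation between the two substitution patterns, unlike the whole-aryl exchange in a 2.6-fold higher number from compound 2 to compound 3 (0.42 log units; beyond the scatter), which also sits on a different core. Nothing measured on these compounds speaks to what lies behind these numbers.

Still open, from the compounds shown here alone, is whether the same shift on the core of compound 2 would also stay within the scatter, and whether the exchange to 2-chlorophenyl would repeat its step on the core of compound 1. Also open, going by these compounds, is how the half-life would respond to an amine or a carboxylic acid in place of the trifluoromethyl, or to a longer chain in place of the benzyl group on the sulfur.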